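The source may hold more compounds than are shown below. What is called first, only, known or untested is meant among the compounds shown, and "the series" means these compounds.

Compound 1 `Cc1ccc(C(=O)Nc2sc3c(c2C(N)=O)CCN(C(=O)Nc2ccccc2Cl)C3)cc1` and compound 2 `NC(=O)c1c(NC(=O)c2cccc([N+](=O)[O-])c2)sc2c1CCN(C(=O)Nc1ccccc1Cl)C2` share one core. In a functional assay on HL-60 cells (Homo sapiens) for antiproliferative activity, with a stated time of 24 h (a lower number here means a stronger inhibitor, a higher number a weaker inhibitor), compound 1 gives 14600 nM and compound 2 gives 18500 nM. The change between them is 3-nitrophenyl in place of 4-methylphenyl on a carbonyl carbon, and it made a 1.3-fold higher number from compound 1 to compound 2 (0.10 log units; within the scatter). Compound 3 `Cc1ccc(C(=O)Nc2sc3c(c2C(N)=O)CCN(C(=S)Nc2cc(C(F)(F)F)cc(C(F)(F)F)c2)C3)cc1` carries a core different from that of compound 1; the difference between the two cores is not broken down here. In this assay compound 3 gives 11800 nM, a number within the scatter of both compound 1 and compound 2, so no order among the three is read. Compound 4 `NC(=O)c1c(NC(=O)c2cccc([N+](=O)[O-])c2)sc2c1CCN(C(=S)Nc1cc(C(F)(F)F)cc(C(F)(F)F)c1)C2` is not yet measured. It stands to compound 3 as compound 2 stands to compound 1, the change being (3-nitrophenyl in place of 4-methylphenyl on a carbonyl carbon), the same change at the same place, a carbonyl carbon whose other neighbour is an amide-type nitrogen; among the compounds shown it occurs twice in all. Going by the values given here, the expected step is a 1.3-fold higher number from compound 3 to compound 4 (0.10 log units; within the scatter), resting on the single measured instance of this change, a 1.3-fold higher number from compound 1 to compound 2 (0.10 log units; within the scatter), which stayed within the scatter. Compound 4 is therefore estimated at 15000 nM in this assay, with a range from 8000 nM to 28000 nM.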

Compound 4, half-maximal inhibitory concentration: 16400 nM
Compound 4: the middle estimate sits 1.1-fold (0.04 log units) below what was measured; the measured number falls inside the stated range.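

In this assay 3-nitrophenyl in place of 4-methylphenyl on the carbonyl carbon gives a 1.4-fold higher number from compound 3 to compound 4 (0.14 log units; within the scatter) on the second core as well. Set beside the earlier step, the change carries from the core of compound 1 to the core of compound 3 with no difference that can be read: the same change on two cores in this assay, a 1.3-fold higher number (0.10 log units; within the scatter) from compound 1 to compound 2 and a 1.4-fold higher number (0.14 log units; within the scatter) from compound 3 to compound 4, 1.1-fold (0.04 log units) apart, within the scatter of two such steps. This shows only that the change leaves the number within the scatter on both cores; it shows no real effect of the change on either core, and two instances in one assay say nothing about cores not shown.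

Still open, from the compounds shown here alone, is whether any other group on this carbonyl carbon moves the number beyond the scatter, for instance a phenyl ring carrying an amine or a carboxylic acid, or a longer chain in place of the ring. Also open is which part of the difference between the two cores matters, if any, as no pair shown alters a single place of it.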